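The compounds below may be only part of what the source reports. "The series", "measured", "known", "first", "only" and "open" are said of these compounds alone.

Measured so far in a toxicity assay on HepG2 cells (Homo sapiens) for inhibition, read by CellTiter-Glo, with a stated time of 48 h; a lower number here means a stronger inhibitor, a higher number a weaker inhibitor:

Compound 1 `COc1ccc2nc(C)cc(OCC(=O)Nc3cc(C)ccc3C)c2c1` — compound 1 reaches only the assay limit, > 100000 nM.
Compound 2 `COc1ccc2nc(C)cc(OCC(=O)Nc3c(C)cccc3C)c2c1` — compound 2 likewise reaches only the assay limit, > 100000 nM.
Compound 3 `COc1ccc2nc(C)cc(OCC(=O)Nc3ccccn3)c2c1` — compound 3 also reaches only the assay limit, > 100000 nM.

Compound 3 therefore stands where every measured member of the series stands: at the limit of this assay, as the limit of > 100000 nM in this assay, at which 3 of the 3 values shown sit, records. None of the three steps between measured compounds can be read. As far as these compounds go, the step that the two limits leave unreadable from compound 1 to compound 2, the step that the two limits leave unreadable from compound 1 to compound 3 and the step that the two limits leave unreadable from compound 2 to compound 3 all run between two limits, so their sizes are unknown; none of them shows a change in this assay within the range the assay can report.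

Compound 4 `COc1ccc2nc(C)cc(OCC(=O)NNC(=O)c3ccncc3)c2c1` is the next member to be measured. It differs from compound 3 by ((pyridin-4-yl)carbonyl)amino in place of pyridin-2-yl on an amide-type nitrogen. Within the data shown here, no measured step bears on this change, since all three steps are unreadable and the amide-nitrogen substituent has so far never produced a readable number.

With three members at the limit, compound 4 is expected to remain at or near that limit, with an expected step of a number no higher from compound 3 to compound 4 (the limit leaves the size open) that cannot be distinguished from no change. The estimate for compound 4 is 100000 nM, within 30000 nM to 300000 nM, and most likely reported only as a limit.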

Compound 4, half-maximal inhibitory concentration: > 100000 nM
Compound 4 gave a limit, no number; the forecaster's own chance of this, stated with the estimate: 85%; the middle value sits exactly at the limit.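

In this assay the steps from compound 1, compound 2 and compound 3 to compound 4 cannot be read, because both ends of each step are limits: the limit of > 100000 nM in this assay, at which 4 of the 4 values shown sit.

Whether any substituent on the amide-type nitrogen gives a readable number in this assay stays open, as does any true difference among these four compounds.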